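A few compounds are considered here, and "the series" means these few. Any claim that something is new, unique, unknown or untested is made for them only; others in the source may bear on it.

Two hydroxamic acids from the same series have been tested in a functional assay on HCT-15 cells (Homo sapiens) for antiproliferative activity; a lower number here means a stronger inhibitor of growth, a higher number a weaker inhibitor of growth. Compound 1 `O=C(CCC1=CCN(Cc2ccc(C(F)(F)F)cc2)C1=O)NO` gives 4540 nM in this assay. Compound 2 `COc1ccccc1CN1CC=C(CCC(=O)NO)C1=O` gives > 10000 nM in this assay, which is a limit of the measurement and not a number. Compound 2 therefore stands at the limit of > 10000 nM in this assay, at which 1 of the 2 values shown sits. Compound 3 `O=C(CCC1=CCN(Cc2ccccc2)C1=O)NO` has not yet been measured. It differs from compound 2 in a single place: hydrogen in place of methoxy on an aromatic carbon. Among the compounds with values here, no measured pair here differs in just one place, so the size of this step can only be estimated. Compound 1, which carries another group on the same ring, reaches 4540 nM, so the change is not expected to carry compound 3 far past that region. The step from compound 2 to compound 3 is estimated at an at least 1.2-fold lower number from compound 2 to compound 3 (0.09 log units; that floor lies within the scatter), towards stronger inhibition if any. Compound 3 is expected to give 8000 nM in this assay, within 3000 nM and 20000 nM.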

Compound 3, concentration for 50% growth inhibition: 5370 nM
For compound 3 the middle estimate is 1.5-fold (0.17 log units) above the measured one, within the range that was stated.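

In this assay, hydrogen in place of methoxy on this aromatic carbon, ortho to a large group, gives an at least 1.8-fold lower number from compound 2 to compound 3 (0.27 log units; that floor lies within the scatter). This can be read only as a floor, so the real step may be larger, because compound 2 carries a limit of the assay and not a number: the limit of > 10000 nM in this assay, at which 1 of the 3 values shown sits. Changing trifluoromethyl to hydrogen on the same ring gives a 1.2-fold higher number from compound 1 to compound 3 (0.07 log units; within the scatter), so these two groups cannot be told apart in this assay.

The compounds shown leave open whether an amine or a carboxylic acid on this ring would shift growth inhibition beyond the scatter. They also leave open how a longer chain leading to the hydroxamic acid would compare.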